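The source may report more compounds than this note shows. Statements on the series, on what has been measured and on what is new or still open speak of the compounds shown alone.

Compound 1, `COc1cc(CCc2ccc(Br)cc2)cc(OC)c1O` — 1490 nM
Compound 2, `COc1ccc(CCc2ccc([N+](=O)[O-])cc2)cc1OC` — 13700 nM
Compound 3, `COc1cc(CCc2ccccc2F)cc(OC)c1O` — > 25000 nM

Of the compounds shown here, three have been measured in a functional assay on MKN-45 cells (Homo sapiens) for antiproliferative activity, read by MTT assay, with a stated time of 72 h; a higher number here means a weaker inhibitor, a lower number a stronger inhibitor. Compound 1, which carries a bromo group, gives 1490 nM in this assay. Compound 2, which carries a nitro group, gives 13700 nM. For compound 3 this assay reports only a limit, > 25000 nM, and no number. Compound 3 therefore stands at the limit of > 25000 nM in this assay, at which 1 of the 3 values shown sits, and how far beyond that edge it lies is not known.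

The next compound, compound 4, is `COc1cc(CCc2ccccc2Cl)cc(OC)c1O`. It differs from compound 3 in one place: chloro in place of fluoro on an aromatic carbon. Going by the values given here, no pair of measured compounds differs in a single place, so the measured set gives no yardstick for how much one such change shifts the value in this assay. The exchange of one halogen for another of the same kind of position is expected to move the number little, and whether any gain rises beyond the scatter cannot be told from compounds 1, 2 and 3. Compound 4 is expected to remain weak, near 18000 nM, within a range of 6000 nM to 50000 nM. That estimate means an expected step of an at least 1.3-fold lower number from compound 3 to compound 4 (0.14 log units; that floor lies within the scatter). There is a fair chance that this assay again returns only a limit for compound 4.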

Compound 4, half-maximal inhibitory concentration: 24500 nM
The estimate for compound 4 lay 1.4-fold (0.13 log units) below the measured number; the range from low to high includes it.
By their numbers in this assay, from the lowest: compound 1; then compounds 2 and 4 (each within the scatter of the next). At a limit, above all of these: compound 3.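

In this assay, going by these compounds alone, chloro in place of fluoro on an aromatic carbon, ortho to a large group, gives the first step in the set that can be read between two compounds differing in one place: an at least 1.0-fold lower number from compound 3 to compound 4 (0.00 log units; that floor lies within the scatter). This exchange of one halogen for the other, at this position on the six-membered aromatic ring, therefore shows no gain beyond the scatter, although compound 4 gives a measured number, 24500 nM, where its fluoro partner does not. How far the two compounds truly stand apart cannot be read, because compound 3 is held at a limit of the assay and not at a number: the limit of > 25000 nM in this assay, at which 1 of the 4 values shown sits.

The compounds shown leave open whether a group of another kind in this same place, such as an amine or a carboxylic acid, would move the number beyond the scatter. They also leave open whether a bromo group on this carbon would shift the value, or whether the chloro group would give a different number on another carbon of that ring.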